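Nitro in Place of Bromo: Expected Lung-Cell Inhibition

A few compounds are considered here, and "the series" means these few. Any claim that something is new, unique, unknown or untested is made for them only; others in the source may bear on it.

Three compounds have been measured in a functional assay on A549 cells (Homo sapiens) for inhibition, read by CCK-8 assay; on this read-out lower numbers stand for stronger inhibition and higher numbers for weaker inhibition:
compound 1 `Oc1ccccc1/C=N/c1nnc(SCc2nnc(-c3ccccc3)o2)s1` gives 4110 nM
compound 2 `Oc1ccccc1/C=N/c1nnc(SCc2nnc(-c3ccc(Br)cc3)o2)s1` gives 20000 nM
compound 3 `COc1ccc(-c2nnc(CSc3nnc(/N=C/c4ccccc4O)s3)o2)cc1` gives 20300 nM

Compound 2 and compound 3 sit within the scatter of each other, both well away from compound 1: the step of a 4.9-fold higher number from compound 1 to compound 2 (0.69 log units; beyond the scatter) and the step of a 4.9-fold higher number from compound 1 to compound 3 (0.69 log units; beyond the scatter) are both modest weakenings, and the step of a 1.0-fold higher number from compound 2 to compound 3 (0.01 log units; within the scatter) shows that the two groups at that place do not differ. Compound 4 `O=[N+]([O-])c1ccc(-c2nnc(CSc3nnc(/N=C/c4ccccc4O)s3)o2)cc1` is the next variant; relative to compound 2 the change is nitro in place of bromo on an aromatic carbon. Since both earlier groups at this place gave the same number, compound 4 is expected to stay close to compound 2, with a step of no change at the digits printed from compound 2 to compound 4 (within the scatter), not beyond the scatter. Compound 4 is therefore estimated at 20000 nM, ranging from 8000 nM to 50000 nM.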

Compound 4, half-maximal inhibitory concentration: 4130 nM
Beside the measured number, compound 4's estimate is 4.8-fold (0.69 log units) above it; the measured number lies below the stated range.
By their numbers in this assay, from the lowest: compounds 1 and 4 (each within the scatter of the next); then compounds 2 and 3 (each within the scatter of the next).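

Which group sits at this place matters after all: nitro in place of bromo gives a 4.8-fold lower number from compound 2 to compound 4 (0.69 log units; beyond the scatter) and nitro in place of methoxy gives a 4.9-fold lower number from compound 3 to compound 4 (0.69 log units; beyond the scatter) as well. The unsubstituted ring offers no gain to set against this, with a 1.0-fold higher number from compound 1 to compound 4 (0.00 log units; within the scatter) showing no difference, so only bromo and methoxy weaken inhibition among the groups shown. No measurement here explains why nitro parts from those two groups. Still open, on these data alone, is whether an amine or a carboxylic acid at this place would match compound 1 and compound 4 or compound 2 and compound 3.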